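One Ring Swap on a Carbonyl Carbon

A few compounds are considered here, and "the series" means these few. Any claim that something is new, unique, unknown or untested is made for them only; others in the source may bear on it.

Compound 1 (`CCCCCCCCCCCC[C@@H](O)[C@H]1CC[C@H]([C@H](O)CCCCCCCCCCNC(=O)c2ccoc2)O1`) and compound 2 (`CCCCCCCCCCCC[C@@H](O)[C@H]1CC[C@H]([C@H](O)CCCCCCCCCCNC(=O)c2cncs2)O1`) share the same core and differ only in the ring attached to an amide carbonyl. In a functional assay on DU-145 cells (Homo sapiens) for inhibition, read by colorimetric assay and sulforhodamine B assay, with a stated time of 48 h (on this read-out higher numbers stand for weaker inhibition of growth and lower numbers for stronger inhibition of growth), compound 1 gives 100000 nM and compound 2 gives 100000 nM in the same test, so compound 2 stands level with compound 1. Among the measured compounds shown here, the one measured step is no change at the digits printed from compound 1 to compound 2 (within the scatter) and it places 1,3-thiazol-5-yl where furan-3-yl stood.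

Compound 3 (`CCCCCCCCCCCC[C@@H](O)[C@H]1CC[C@H]([C@H](O)CCCCCCCCCCNC(=O)c2ccsc2)O1`) changes that same place again. Here thiophen-3-yl stands in place of 1,3-thiazol-5-yl on a carbonyl carbon (thiophen-3-yl in place of 1,3-thiazol-5-yl on a carbonyl carbon). For the measured compounds named here, each of these two groups is one five-membered aromatic ring, and the only earlier ring exchange here produced no visible shift. A single step is thin evidence, yet it offers no reason to predict movement in either direction. The expected step is no change at the digits printed from compound 2 to compound 3 (within the scatter) and no shift beyond the usual scatter is anticipated in this assay on this evidence. For compound 3 the estimated value is 100000 nM with an expected range from 40000 nM to 120000 nM as the likely span.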

Compound 3, concentration for 50% growth inhibition: 2190 nM
Estimate against measurement, compound 3: 46-fold (1.66 log units) above, and the stated range ends above it.
By their numbers in this assay, from the lowest: compound 3; then compounds 1 and 2 (each within the scatter of the next).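

Changing the ring on the amide carbonyl can alter growth inhibition sharply: in this assay thiophen-3-yl in place of 1,3-thiazol-5-yl gives a 46-fold lower number from compound 2 to compound 3 (1.66 log units; beyond the scatter) and thiophen-3-yl in place of furan-3-yl gives a 46-fold lower number from compound 1 to compound 3 (1.66 log units; beyond the scatter) in the same test. Ring size alone does not decide the outcome at this position, since all three groups are single five-membered aromatic rings, yet only thiophen-3-yl stands apart, while the furan-3-yl and 1,3-thiazol-5-yl compounds remain level. The change from 1,3-thiazol-5-yl to thiophen-3-yl also takes the count of ring hetero atoms and hydrogen-bond acceptors down by one, but no measurement shown here explains the large difference in growth inhibition.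

From the compounds shown here alone, it remains open whether thiophen-2-yl, or a six-membered ring such as phenyl or pyridin-3-yl, on the same carbonyl carbon would match compound 3 or fall back to the level of the other two compounds. The compounds shown also leave open whether the gain from thiophen-3-yl would survive a shorter chain between the amide nitrogen and the shared core.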